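Removing the cyano group from compound 2

The compounds below may be only part of what the source reports. "The series", "measured", "known", "first", "only" and "open" are said of these compounds alone.

Compound 2 `COc1cc(-c2ccnc3cc(-c4cccc(C#N)c4)nn23)cc(OC)c1OC` reads > 10000 nM in a functional assay on A549 cells (Homo sapiens) for inhibition, read by CCK-8 assay, with a stated time of 48 h (a higher number here means a weaker inhibitor, a lower number a stronger inhibitor), which is a limit of the assay and not a number. Compound 3 `COc1cc(-c2ccnc3cc(-c4ccccc4)nn23)cc(OC)c1OC` has hydrogen in place of cyano on an aromatic carbon. Within the data shown here, one measured step bears on this: an at least 2.6-fold higher number from compound 1 to compound 2 (0.42 log units; beyond the scatter). In this assay compound 1 `COc1cc(-c2ccnc3cc(-c4ccc(F)cc4)nn23)cc(OC)c1OC` gives 3800 nM, so a number is expected again once the cyano has gone, with the direction downward. The expected change is an at least 2.0-fold lower number from compound 2 to compound 3 (0.30 log units; that floor lies within the scatter), a modest step to a lower number. Compound 3 is estimated at 5000 nM, with an expected range of 1800 nM to 12000 nM.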

Compound 3, half-maximal inhibitory concentration: 208 nM
Beside the measured number, compound 3's estimate is 24-fold (1.38 log units) above it; the whole stated range lies above it.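

In this assay the phenyl of compound 3 gives the lowest reading of the series: hydrogen in place of cyano gives an at least 48-fold lower number from compound 2 to compound 3 (1.68 log units; beyond the scatter), and hydrogen in place of fluoro gives an 18-fold lower number from compound 1 to compound 3 (1.26 log units; beyond the scatter). On this ring, then, neither 3-cyanophenyl nor 4-fluorophenyl matches plain phenyl, and both replacements by hydrogen are large steps. The step from the nitrile rests on a limit of the assay for compound 2, not a number: the limit of > 10000 nM in this assay, at which 1 of the 3 values shown sits.

Open: whether a methyl or an amine on this ring would keep the reading of compound 3. Cyano and fluoro also differ in where they sit, so the shown compounds cannot separate group from position.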